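The compounds below may be only part of what the source reports. "The series", "measured", "known", "first", "only" and "open" are said of these compounds alone.

Of the compounds shown here, three sharing one core have so far been tested in a functional assay on A549 cells (Homo sapiens) for cytotoxicity, with a stated time of 48 h; on this read-out higher numbers stand for weaker inhibition and lower numbers for stronger inhibition. Compound 3 `CCC(=O)Oc1ccc2oc(/C=C/[S+](C)[O-])cc(=O)c2c1`, which carries propanoyloxy on an aromatic carbon, gives 2400 nM. Compound 1 `CCCC(=O)Oc1ccc2oc(/C=C/[S+](C)[O-])cc(=O)c2c1`, with (propylcarbonyl)oxy on that carbon, gives 2200 nM, and compound 2 `C[S+]([O-])/C=C/c1cc(=O)c2cc(Cl)ccc2o1`, with chloro, gives 1700 nM. These three numbers all lie within the usual scatter of one another, so compound 3 stands level with both of the others.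

The next structure is compound 4 `CC(C)C(=O)Oc1ccc2oc(/C=C/[S+](C)[O-])cc(=O)c2c1`. The change is methyl in place of hydrogen on a saturated chain carbon bound to a carbonyl carbon and a saturated chain carbon, which turns propanoyloxy into (isopropylcarbonyl)oxy.

The closest measured comparison is a 1.1-fold higher number from compound 1 to compound 3 (0.04 log units; within the scatter). That step also exchanges methyl and hydrogen on the same side chain, but on a carbon two bonds along the chain from a carbonyl carbon, so it is a guide and not a copy. A much larger swap of the whole group gives a 1.4-fold higher number from compound 2 to compound 3 (0.15 log units; within the scatter), and that too stays within the scatter. Going by the values given here, no measured step here has yet moved the number beyond the scatter, although only three compounds support this.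

The expected step is a 1.0-fold lower number from compound 3 to compound 4 (0.02 log units; within the scatter), so no move beyond the scatter is anticipated. Compound 4 is estimated at 2300 nM, with an expected range from 1200 nM to 4400 nM.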

Compound 4, half-maximal inhibitory concentration: 2400 nM
Beside the measured number, compound 4's estimate is 1.0-fold (0.02 log units) below it, within the range that was stated.
By their numbers in this assay, from the lowest: compounds 2, 1, 3 and 4 (each within the scatter of the next).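

In this assay, methyl in place of hydrogen on the saturated chain carbon bound to the carbonyl carbon gives no change at the digits printed from compound 3 to compound 4 (within the scatter). The earlier compounds shown here had tested this exchange only on a carbon two bonds along the chain from a carbonyl carbon, so the new result extends the same outcome to a second carbon of the side chain, and the branched and straight chains of equal carbon count also stand level, with isopropyl in place of propyl on a carbonyl carbon giving a 1.1-fold higher number from compound 1 to compound 4 (0.04 log units; within the scatter). Replacing chloro with the whole (isopropylcarbonyl)oxy group gives a 1.4-fold higher number from compound 2 to compound 4 (0.15 log units; within the scatter), so all four compounds remain level and no step shown so far leaves the scatter.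

No measurement shown here offers an explanation for why these numbers stay so close together. As far as these compounds go, it remains open whether a bulkier chain such as tert-butyl, or a different kind of group such as an amine or a carboxylic acid on the side chain, would move the number beyond the scatter.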